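Methoxy on the phenyl: will the high efficacy hold?

A few compounds are considered here, and "the series" means these few. Any claim that something is new, unique, unknown or untested is made for them only; others in the source may bear on it.

Measured compounds:
compound 1 `COc1ccccc1Nc1nc(-c2ccc(F)cc2)c(CC(=O)O)s1`, a limit of > 70%.
compound 2 `COc1ccc(-c2nc(-c3ccc(OC)cc3)c(CC(=O)O)s2)cc1`, a limit of > 70%.
compound 3 `O=C(O)Cc1sc(Cc2ccc(Cl)cc2)nc1-c1ccccc1`, a limit of > 70%.

All three were tested in an in vitro functional assay on HEK285-7 cells for antagonist activity at prostaglandin D2 receptor 2 (Homo sapiens), read by BRET and beta-arrestin recruitment; on this read-out higher numbers stand for larger maximal responses and lower numbers for smaller maximal responses. For compound 3 the value is a limit of the assay, not a number, and the same holds for the two others, so compound 3 stands where every compound here stands: the limit of > 70% in this assay, at which 3 of the 3 values shown sit. Compound 4 `COc1ccc(-c2nc(Cc3ccc(Cl)cc3)sc2CC(=O)O)cc1` is its close relative; the change is methoxy in place of hydrogen on an aromatic carbon. For the measured compounds named here, no measured step tells what such a change does in this assay. With nothing pointing either way, the step that the limit leaves unreadable from compound 3 to compound 4 is expected to stay within the usual scatter. Compound 4 is therefore estimated at about 82%, with a range from 62% to 100%.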

Compound 4, largest response reached (reported as efficacy), in percent of the reference or control that the assay uses: > 70%
Compound 4 gave a limit, no number; the forecaster's own chance of this, stated with the estimate: 85%; the middle value is on the limit's open side.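

In this assay compound 4 gives > 70%, which is a limit and not a number, so its steps from compound 3 and compound 2 cannot be read: the limit of > 70% in this assay, at which 4 of the 4 values shown sit.

From the compounds shown here alone, whether methoxy in place of hydrogen changes the response at all stays open.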